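A few compounds are considered here, and "the series" means these few. Any claim that something is new, unique, unknown or untested is made for them only; others in the source may bear on it.

Three compounds of the series have been run in a functional assay on MCF7 cells (Homo sapiens) for antiproliferative activity, read by MTT assay, with a stated time of 48 h; a lower number here means a stronger inhibitor, a higher number a weaker inhibitor. Compound 1 `Cc1ccc2nc(Nc3ccnc(Nc4ccc(S(C)(=O)=O)cc4)n3)sc2c1` gives only a limit in this assay, > 50000 nM, and no number. Compound 2 `NS(=O)(=O)c1ccc(Nc2nccc(Nc3nc4ccc(F)cc4s3)n2)cc1` gives 10900 nM in this assay. Compound 3 `CS(=O)(=O)c1ccc(Nc2ncc(F)c(Nc3nc4ccccc4s3)n2)cc1` gives 6880 nM in this assay, the lowest of the two numbers shown; the gap between compound 3 and compound 2 lies within the scatter, so no order between them is claimed. Within the data shown here, no two measured compounds differ in a single place, so no measured step is available to lean on.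

Compound 4 `Cc1cnc(Nc2ccc(S(C)(=O)=O)cc2)nc1Nc1nc2ccccc2s1` has not been measured. It differs from compound 3 by methyl in place of fluoro on an aromatic carbon, the change sitting on an aromatic carbon of a six-membered aromatic ring with 2 nitrogen, ortho to a large group, two atoms from the ring nitrogen and para to a large group. Among the measured compounds shown here, with no measured step to guide it, the step in this assay is expected to be no larger than the scatter, or at most a modest loss, as a 1.5-fold higher number from compound 3 to compound 4 (0.16 log units; within the scatter). Compound 4 is therefore estimated at 10000 nM in this assay, with a range from 3000 nM to 40000 nM, anchored on compound 3 because compound 3 stands at 6880 nM.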

Compound 4, half-maximal inhibitory concentration: 6550 nM
Compound 4: the middle estimate sits 1.5-fold (0.18 log units) above what was measured; the measured number falls inside the stated range.
By their numbers in this assay, from the lowest: compounds 4, 3 and 2 (each within the scatter of the next). At a limit, above all of these: compound 1.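

Among these compounds, this is the first single-place step, on an aromatic carbon of a six-membered aromatic ring with 2 nitrogen: in this assay, methyl in place of fluoro gives a 1.1-fold lower number from compound 3 to compound 4 (0.02 log units; within the scatter). At this position, ortho to a large group and para to a large group, fluoro can therefore be exchanged for methyl without a change beyond the scatter. Nothing measured here bears on why the two groups read alike.

Going by these compounds, whether methoxy, an amine or a carboxylic acid on this same carbon would also leave the number within the scatter of compound 4 stays open. Also open, on these data alone, is whether methyl and fluoro would read alike at this position on the core of compound 2.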